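Azidomethyl exchange on the acyl group

A few compounds are considered here, and "the series" means these few. Any claim that something is new, unique, unknown or untested is made for them only; others in the source may bear on it.

Measured in a functional assay on MGC-803 cells (Homo sapiens) for inhibition, read by MTT assay, with a stated time of 48 h (a higher number here means a weaker inhibitor, a lower number a stronger inhibitor), as follows
- compound 1 `COc1ccc(CN(C(=O)C(C)Br)c2cc(OC)c(OC)c(OC)c2)cc1O` gives 120 nM
- compound 2 `CCC/C=C/C(=O)N(Cc1ccc(OC)c(O)c1)c1cc(OC)c(OC)c(OC)c1` gives 70 nM
- compound 3 `CC/C=C/C(=O)N(Cc1ccc(OC)c(O)c1)c1cc(OC)c(OC)c(OC)c1` gives 58 nM

Compound 3 gives 58 nM and stands level with its nearest neighbour (a 1.2-fold lower number from compound 2 to compound 3 (0.08 log units; within the scatter)) while lying clear of the furthest one (a 2.1-fold lower number from compound 1 to compound 3 (0.32 log units; beyond the scatter)). Compound 4 `COc1ccc(CN(C(=O)CN=[N+]=[N-])c2cc(OC)c(OC)c(OC)c2)cc1O` carries azidomethyl in place of but-1-en-1-yl on a carbonyl carbon. The closest evidence is the other exchange at that carbonyl carbon, from 1-bromoethyl to an alkenyl group (a 1.7-fold lower number from compound 1 to compound 2 (0.23 log units; within the scatter); a 2.1-fold lower number from compound 1 to compound 3 (0.32 log units; beyond the scatter)). The chain-length step among the alkenyl compounds says little here. Among the compounds with values here, no azide has been measured, and compound 1 (120 nM) is the only member without an alkenyl group. A modest step towards a higher number is therefore expected in this assay with low confidence. The estimated step is a 1.7-fold higher number from compound 3 to compound 4 (0.24 log units; within the scatter) on this reading. For compound 4 the expected value is 100 nM (estimated range 35 nM to 280 nM).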

Compound 4, half-maximal inhibitory concentration: 120 nM
Compound 4: middle estimate off by 1.2-fold (0.08 log units), on the low side, within the range that was stated.
By their numbers in this assay, from the lowest: compounds 3, 2, 1 and 4 (each within the scatter of the next, the first and the last beyond it).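

In this assay, within the data shown here, azidomethyl on the carbonyl carbon is the only group here that carries nitrogen, and its exchange for but-1-en-1-yl gives a modest step (a 2.1-fold higher number from compound 3 to compound 4 (0.32 log units; beyond the scatter)). The same group does not separate from the other two: 1-bromoethyl reads alike (no change at the digits printed from compound 1 to compound 4 (within the scatter)), and the step from pent-1-en-1-yl also stays small (a 1.7-fold higher number from compound 2 to compound 4 (0.23 log units; within the scatter)), so compound 2 goes against any clean split between alkenyl and non-alkenyl groups. No measurement shown gives a reason for these steps.

On these data alone, it remains open whether other non-alkenyl acyl groups, such as acetyl or a saturated butyl chain, would read like azidomethyl and 1-bromoethyl. As far as these compounds go, it is also open whether the azide itself matters, or whether an aminomethyl or cyanomethyl group at the same carbonyl carbon would read the same.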